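This account rests on a few compounds, and the source may have more. Where it says the series, first, only, none or still open, it means among the compounds named here.

Measured so far:
Compound 1 `COc1ccc(C(=O)/C=C/c2ccc(OCc3cn(Cc4ccccc4Br)nn3)cc2)cc1` gives 50% in a functional assay on MIA PaCa-2 cells (Homo sapiens) for inhibition, read by MTT assay, with a stated time of 48 h, tested at 10 uM; a higher number here means more inhibition of growth at the concentration tested, a lower number less inhibition of growth.
Compound 2 `COc1ccc(C(=O)/C=C/c2ccc(OCc3cn(Cc4cccc(Br)c4)nn3)cc2)cc1` gives 50% in this assay.
Compound 3 `O=C(/C=C/c1ccc(OCc2cn(Cc3ccccc3Br)nn2)cc1)c1ccc([N+](=O)[O-])cc1` gives 34% in this assay.

Compound 4 `O=C(/C=C/c1ccc(OCc2cn(Cc3cccc(Br)c3)nn2)cc1)c1ccc([N+](=O)[O-])cc1` has not yet been measured. It differs from compound 3 by one change, (3-bromophenyl in place of 2-bromophenyl on a saturated chain carbon bound to an aromatic nitrogen). The same change, (3-bromophenyl in place of 2-bromophenyl on a saturated chain carbon bound to an aromatic nitrogen), has already been made between two measured compounds, and there it gave no change at the digits printed from compound 1 to compound 2 (within the scatter). The two cores on which this change is made differ in one place, (nitro in place of methoxy on an aromatic carbon), and that difference gave a number 16 percentage points lower from compound 1 to compound 3 (beyond the scatter). Because the earlier step of no change at the digits printed from compound 1 to compound 2 (within the scatter) stayed within the scatter, the expected step from compound 3 to compound 4 is also small, no change at the digits printed from compound 3 to compound 4 (within the scatter). Going by the values given here, for compound 4 the expected value in this assay is therefore estimated at 34%, most likely between 22% and 46%, resting on the value of compound 3, 34%, and on the single measured example of this change.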

Compound 4, percent growth inhibition at one concentration: 21%
Compound 4: middle estimate off by 13 percentage points, on the high side; the measured number lies below the stated range.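

On the core of compound 3, 3-bromophenyl in place of 2-bromophenyl gives a number 13 percentage points lower from compound 3 to compound 4 (beyond the scatter) in this assay, yet this step does not clearly differ from the one on the core of compound 1: the same change on two cores in this assay, no change at the digits printed (within the scatter) from compound 1 to compound 2 and a number 13 percentage points lower (beyond the scatter) from compound 3 to compound 4, 13 percentage points apart, within the scatter of two such steps. Nitro in place of methoxy gives a number 29 percentage points lower from compound 2 to compound 4 (beyond the scatter), and this step also agrees with its earlier counterpart: the same change on two cores in this assay, a number 16 percentage points lower (beyond the scatter) from compound 1 to compound 3 and a number 29 percentage points lower (beyond the scatter) from compound 2 to compound 4, 13 percentage points apart, within the scatter of two such steps. These four compounds therefore give no clear sign that either change depends on the core, but a single pair of cores cannot show that the steps hold on other cores. As far as these compounds go, it remains open whether the same holds with an amine, a carboxylic acid or a longer chain in place of the nitro or methoxy group.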